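Swapping a large side group on the nitrogen

The compounds below may be only part of what the source reports. "The series", "measured", "known", "first", "only" and "open" are said of these compounds alone.

Measured so far in a functional assay on K562 cells (Homo sapiens) for cytotoxicity, read by trypan blue exclusion, with a stated time of 96 h; a lower number here means a stronger inhibitor, a higher number a weaker inhibitor

Compound 1 `COC(=O)C(Nc1cc(NS(=O)(=O)/C=C/c2c(OC)cc(OC)cc2OC)ccc1OC)c1ccccc1` gives 2500 nM
Compound 2 `COC(=O)C(Nc1cc(NS(=O)(=O)/C=C/c2c(OC)cc(OC)cc2OC)ccc1OC)c1ccc(Br)cc1` gives 1000 nM

Compound 2 has the lower of the two numbers (1000 nM) and is therefore the stronger inhibitor so far. Compound 3 `COc1cc(OC)c(/C=C/S(=O)(=O)Nc2ccc(OC)c(NC(C)(C)C(=O)O)c2)c(OC)c1` has not yet been measured. The structural change from compound 2 is large (1-carboxy-1-methylethyl in place of (4-bromophenyl)(methoxycarbonyl)methyl on a nitrogen on an aromatic ring), with 1-carboxy-1-methylethyl in place of (4-bromophenyl)(methoxycarbonyl)methyl on a nitrogen on an aromatic ring.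

Among the measured compounds shown here, only one measured step bears on this (a 2.5-fold lower number from compound 1 to compound 2 (0.40 log units; beyond the scatter)), and it was modest. In that step a bromo took the place of hydrogen on an aromatic carbon. The bromo leaves along with its ring in the new change, so that modest gain may be lost as well. For the measured compounds named here, no measured compound shows what losing the whole group does, so the size of the step stays uncertain. A modest move towards a higher number in this assay is expected. The expected change is a 2.0-fold higher number from compound 2 to compound 3 (0.30 log units; within the scatter) and is only a rough estimate. The estimated value for compound 3 is 2000 nM (expected range 300 nM to 10000 nM).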

Compound 3, half-maximal inhibitory concentration: 5 nM
For compound 3 the middle estimate is 400-fold (2.60 log units) above the measured one; measured number below the stated range.
By their numbers in this assay, from the lowest: compound 3; then compound 2; then compound 1.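

In this assay, the group on the nitrogen on an aromatic ring counts for far more than the bromo did: the earlier change gave only a 2.5-fold lower number from compound 1 to compound 2 (0.40 log units; beyond the scatter), whereas the new one gives a 200-fold lower number from compound 2 to compound 3 (2.30 log units; beyond the scatter) and, measured against the compound without bromo, a 500-fold lower number from compound 1 to compound 3 (2.70 log units; beyond the scatter). The large (4-bromophenyl)(methoxycarbonyl)methyl group is therefore not needed for a low number at this position, and 1-carboxy-1-methylethyl, which has fewer heavy atoms, no ring and a hydrogen-bond donor, does much better in its place. No supporting measurement is available to explain why this swap has such a large effect.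

The swap removes the ring and replaces the methoxycarbonyl with a carboxylic acid in a single move, and the compounds shown cannot separate these two parts of the change. A methyl ester or a primary amide in place of the carboxylic acid, with the rest of 1-carboxy-1-methylethyl kept, would show how much of the step depends on the carboxylic acid itself.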